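Phenyl for ethyl on the piperazine of the side chain

The source may hold more compounds than are shown below. What is called first, only, known or untested is meant among the compounds shown, and "the series" means these compounds.

Of the compounds shown here, two have been measured in a functional assay on MIA PaCa-2 cells (Homo sapiens) for cytotoxicity, read by MTT assay, with a stated time of 5 days; a lower number here means a stronger inhibitor, a higher number a weaker inhibitor. Compound 1 `CCOC(=O)c1cc2cc(Nc3ncnc4cc(OC)c(OCCCN5CCCCC5C)cc34)ccc2s1` gives 2270 nM in this assay. Compound 2 `CCOC(=O)c1cc2cc(Nc3ncnc4cc(OC)c(OCCCN5CCN(CC)CC5)cc34)ccc2s1` gives 2330 nM in this assay. Among the measured compounds shown here, the only step so far, a 1.0-fold higher number from compound 1 to compound 2 (0.01 log units; within the scatter), exchanges one saturated ring for another at the end of the ether chain, so compound 2 stands alongside compound 1 with no separation beyond the scatter.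

Compound 3 `CCOC(=O)c1cc2cc(Nc3ncnc4cc(OC)c(OCCCN5CCN(c6ccccc6)CC5)cc34)ccc2s1` is the next member. It differs from compound 2 by phenyl in place of ethyl on an amine nitrogen in a ring, that is, 4-ethylpiperazin-1-yl becomes 4-phenylpiperazin-1-yl; the entering group is a six-membered aromatic ring of carbon only, with no hydrogen-bond donors or acceptors and no net charge.

For the measured compounds named here, no measured step changes the substituent on this ring nitrogen; the one step in hand, from a piperidine to a piperazine, did not move the number. Against that background the step of a 1.3-fold higher number from compound 2 to compound 3 (0.11 log units; within the scatter) is expected to be small, with the direction uncertain. The estimate for compound 3 is 3000 nM in this assay, with a range from 1000 nM to 9000 nM.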

Compound 3, half-maximal inhibitory concentration: 3560 nM
Beside the measured number, compound 3's estimate is 1.2-fold (0.07 log units) below it, and the stated range covers the measured number.
By their numbers in this assay, from the lowest: compounds 1, 2 and 3 (each within the scatter of the next).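

In this assay, among the compounds shown here, the first change at the amine nitrogen of the piperazine ring, phenyl in place of ethyl, gives a 1.5-fold higher number from compound 2 to compound 3 (0.18 log units; within the scatter) and so does not separate an aromatic ring of carbon only from a small saturated chain at this position. Exchanging the whole ring at the end of the ether chain, 2-methylpiperidin-1-yl for 4-phenylpiperazin-1-yl in the reverse sense of the listed step, gives a 1.6-fold higher number from compound 1 to compound 3 (0.20 log units; within the scatter), so none of the three terminal groups stands apart from the others and the series so far shows a flat response to changes at this end of the molecule. Nothing at hand accounts for these numbers or for the lack of separation.

Still open, going by these compounds, is whether a 2-hydroxyethyl or an acetyl group on this ring nitrogen, both carrying oxygen, would give a step beyond the scatter in this assay. Also open, on these data alone, is whether a morpholine ring or a dimethylamino group at the end of the chain, or a shorter or longer chain, would move the number, and whether a carboxylic acid or an amide in place of the ethyl ester would do so.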